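Adding a Methyl to the Core of Compound 1

The compounds below may be only part of what the source reports. "The series", "measured", "known", "first", "only" and "open" are said of these compounds alone.

Within the data shown here, compound 1 `O=[N+]([O-])c1cnc2c(Br)cc(Cl)cn12` is the only compound here with a measured number. In an ADME assay on HepG2 cells (Homo sapiens) for cytotoxicity, read by MTT assay, with a stated time of 72 h (on this read-out higher numbers stand for lower toxicity in this test and lower numbers for higher toxicity in this test), compound 1 gives 16200 nM. Compound 2 `Cc1cc(Sc2ccc(Cl)cc2)c2nc(CS(=O)(=O)c3ccccc3)c([N+](=O)[O-])n2c1` provides no number for comparison, only a limit of the assay at > 62500 nM. The next compound to be tested is compound 3 `Cc1nc2c(Br)cc(Cl)cn2c1[N+](=O)[O-]`, which keeps the core of compound 1 and has methyl in place of hydrogen on an aromatic carbon. This carbon lies on the five-membered aromatic ring, next to the ring atom that bears a nitro group. Among the measured compounds shown here, no pair of measured compounds differing in one place is available to size such a change in this assay, so no step beyond the scatter is expected in either direction. The expected step of a 1.2-fold higher number from compound 1 to compound 3 (0.09 log units; within the scatter) is therefore small. For compound 3 the estimated value is 20000 nM, with an expected range of 8000 nM to 50000 nM.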

Compound 3, half-maximal cytotoxic concentration: > 125000 nM
Compound 3: only a limit was reported; the forecaster's own chance of this, stated with the estimate: 15%; middle value at least 6.2-fold (0.79 log units) from the limit.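

With this step, the carbon next to the ring atom that bears a nitro group has its first measured pair in this assay: an at least 7.7-fold higher number from compound 1 to compound 3 (0.88 log units; beyond the scatter). On this read-out a higher number stands for lower toxicity in this test, so a single methyl in place of hydrogen at this carbon is enough to move the shared core beyond the scatter, in the direction of lower toxicity. The step is open at its upper end because the reading for compound 3 is a limit of the assay and not a number: the limit of > 125000 nM in this assay, at which 1 of the 3 values shown sits.

The compounds shown leave open whether a longer chain such as ethyl, an amine or a carboxylic acid on this same carbon would move the number the same way. They also leave open whether the step would hold with the bromine or the chlorine of the shared core replaced.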